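Larger side chain on an alanine ester of the chloro core

The compounds below may be only part of what the source reports. "The series", "measured", "known", "first", "only" and "open" are said of these compounds alone.

Measured compounds in a functional assay on the whole organism (Tail, strain ICR) with Mus musculus as the target, in the tail flick test, with a stated time of 60 min, at a dose of 25 umol/kg by the oral route; a lower number here means a weaker effect, a higher number a stronger effect of the compound at the dose given:
Compound 1 `C[C@H](NC(=O)CN(c1nc(Cl)nc2[nH]cnc12)C1CC1)C(=O)OCc1ccccc1` gives 64.3%.
Compound 2 `O=C(CN(c1ncnc2c1ncn2C1CCCCO1)C1CC1)NCC(=O)OCc1ccccc1` gives 40.4%.
Compound 3 `CC[C@H](C)[C@H](NC(=O)CN(c1ncnc2c1ncn2C1CCCCO1)C1CC1)C(=O)OCc1ccccc1` gives 27.4%.

Compound 1 stands highest of the three in this assay, with compound 2 nearest and compound 3 furthest, both beyond the scatter. The unmeasured compound 4 `CSCC[C@H](NC(=O)CN(c1nc(Cl)nc2[nH]cnc12)C1CC1)C(=O)OCc1ccccc1` differs from compound 1 in one place: (methylsulfanyl)methyl in place of hydrogen on a saturated chain carbon, two bonds along the chain from an amide-type nitrogen and a carbonyl carbon.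

Among the compounds with values here, the only measured step that speaks to such a change is the one from compound 2 to compound 3, where a larger group replaced hydrogen on the saturated chain carbon bound to the amide-type nitrogen and the carbonyl carbon, and the read-out fell a number 13 percentage points lower from compound 2 to compound 3 (beyond the scatter). That pair carries a different core substituent, so it is only a loose guide, and the change here is cut one bond further out. Still, a modest fall is the expectation, and compound 4 is expected to show a number 14.3 percentage points lower from compound 1 to compound 4 (beyond the scatter). Compound 4 is therefore estimated at 50%, within a range from 30% to 70%.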

Compound 4, a percentage reported as activity, at one dose (the size of the read-out at that dose, not a potency): 30.8%
Beside the measured number, compound 4's estimate is 19.2 percentage points above it, and the stated range covers the measured number.
By their numbers in this assay, from the lowest: compounds 3, 4 and 2 (each within the scatter of the next, the first and the last beyond it); then compound 1.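

With the chlorine-bearing core held fixed in this assay, going from methyl to 2-(methylsulfanyl)ethyl gives a number 33.5 percentage points lower from compound 1 to compound 4 (beyond the scatter), a large step. Within the data shown here, the only earlier step at a comparable carbon, a number 13 percentage points lower from compound 2 to compound 3 (beyond the scatter), was modest and involved sec-butyl on a different core, so the new result shows that a fall also occurs on this core and with a chain that carries sulfur. In the two pairs shown, a larger group on this chain lowers the read-out and neither pair goes against that, but no measurement given here accounts for the fall.

Still open, from the compounds shown here alone, is whether a plain n-butyl chain at this carbon would give the same fall, which would separate the part played by the sulfur atom from that of chain length. Going by these compounds, how an amine or a carboxylic acid at the end of this chain would fare also remains open.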